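The compounds below may be only part of what the source reports. "The series", "measured", "known", "first", "only" and "open" are said of these compounds alone.

Measured so far in a functional assay on HepG2 cells (Homo sapiens) for antiproliferative activity, read by XTT assay, with a stated time of 72 h; on this read-out lower numbers stand for stronger inhibition and higher numbers for weaker inhibition:

Compound 1, `Cc1ncnc2c1c(-c1cc3ccccc3o1)cn2[C@@H]1O[C@H](CO)[C@@H](O)[C@H]1O`: compound 1 gives only a limit of the assay, > 20000 nM.
Compound 2, `Cc1ncnc2c1c(-c1ccoc1)cn2[C@@H]1O[C@H](CO)[C@@H](O)[C@H]1O`: compound 2 gives 5320 nM.
Compound 3, `Cc1nc(N)c2c(-c3ccoc3)cn([C@@H]3O[C@H](CO)[C@@H](O)[C@H]3O)c2n1`: compound 3 gives only a limit of the assay, > 20000 nM.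

Compounds 1 and 2 share a core and differ in one place: 1-benzofuran-2-yl in place of furan-3-yl on an aromatic carbon. That change gave an at least 3.7-fold higher number from compound 2 to compound 1 (0.57 log units; beyond the scatter). The size of the step is known only as a bound, because the limit of > 20000 nM in this assay, at which 2 of the 3 values shown sit, caps what can be told of compound 1. Compound 3 carries a different core; how it differs from the core of compound 2 is not broken down here.

Compound 4, `Cc1nc(N)c2c(-c3cc4ccccc4o3)cn([C@@H]3O[C@H](CO)[C@@H](O)[C@H]3O)c2n1`, is not yet measured in this assay. It stands to compound 3 as compound 1 stands to compound 2: 1-benzofuran-2-yl in place of furan-3-yl on an aromatic carbon. The place of the change is the same in both pairs. Since compound 3 already sits at the limit of this assay, > 20000 nM, and the same change moved compound 2 toward weaker inhibition, compound 4 is expected to give a step that the limit leaves unreadable from compound 3 to compound 4, meaning most likely no number at all. Compound 4 is therefore estimated at 60000 nM, with a range from 20000 nM to 200000 nM.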

Compound 4, half-maximal inhibitory concentration: > 20000 nM
Compound 4 gave a limit, no number (the forecaster's own chance of this, stated with the estimate: 95%); the middle value is on the limit's open side.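

In this assay compound 4 gives > 20000 nM, which is a limit of the assay and not a number. No step can be read between compound 3 and compound 4, because neither has a number: the limit of > 20000 nM in this assay, at which 3 of the 4 values shown sit. The compounds shown leave open whether, and by how much, 1-benzofuran-2-yl in place of furan-3-yl changes inhibition on the core of compound 3.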